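The source may report more compounds than this note shows. Statements on the series, on what has been measured and on what is new or still open speak of the compounds shown alone.

Of the compounds shown here, three sharing one core have been measured in an assay on isolated protein for binding affinity to adenosine receptor A1 (Bos taurus); a higher number here means a weaker inhibitor, a lower number a stronger inhibitor. Compound 1 `CNc1nc(-c2ccccc2)nc2c1nnn2Cc1ccccc1Cl` gives 191000000 nM, compound 2 `CCNc1nc(-c2ccccc2)nc2c1nnn2Cc1ccccc1Cl` gives 463000000 nM and compound 3 `Clc1ccccc1Cn1nnc2c(NC3CC3)nc(-c3ccccc3)nc21` gives 11000000 nM. Compound 2 thus has the highest number of the three: a 2.4-fold higher number from compound 1 to compound 2 (0.38 log units; beyond the scatter), and a 42-fold lower number from compound 2 to compound 3 (1.62 log units; beyond the scatter). Every measured step concerns the group on the nitrogen bound to the aromatic ring; the remaining one is a 17-fold lower number from compound 1 to compound 3 (1.24 log units; beyond the scatter).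

Compound 4 `CCNc1nc(-c2ccccc2)nc2c1nnn2Cc1ccccc1` keeps the ethyl of compound 2 and alters a different part: hydrogen in place of chloro on an aromatic carbon. Chloro leaves and hydrogen enters on an aromatic carbon of a six-membered aromatic ring of carbon only, so 2-chlorobenzyl becomes benzyl. Within the data shown here, none of the measured steps touches this position, so they give no direct guide to the size or direction of the change in this assay. With nothing pointing either way, the expected change is a 1.1-fold higher number from compound 2 to compound 4 (0.03 log units; within the scatter), carrying wide uncertainty. Compound 4 is therefore estimated at 500000000 nM, in a range from 150000000 nM to 1500000000 nM.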

Compound 4, inhibition constant: 91000000 nM
Compound 4: middle estimate off by 5.5-fold (0.74 log units), on the high side; measured number below the stated range.
By their numbers in this assay, from the lowest: compound 3; then compound 4; then compound 1; then compound 2.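

Going from 2-chlorobenzyl to benzyl gives a 5.1-fold lower number from compound 2 to compound 4 (0.71 log units; beyond the scatter) in this assay and so makes this aromatic carbon a second place, apart from the group on the nitrogen, where a single change moves the number beyond the scatter. Among these compounds, with the ethyl held fixed, hydrogen at this carbon goes with a stronger inhibitor than chloro does, a direction the earlier compounds could not show. Nothing at hand explains why losing the chloro lowers the number.

Among the compounds shown, benzyl appears only with the ethyl, so it remains open whether the same change would lower the number with the methyl of compound 1 or the cyclopropyl of compound 3. As far as these compounds go, how fluoro, bromo or methoxy on this aromatic carbon would compare with hydrogen and chloro also remains open.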